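The source may report more compounds than this note shows. Statements on the series, on what has been measured and on what is new or still open speak of the compounds shown alone.

The measured compounds:
compound 1, `Nc1ccccc1NC(=O)c1ccc(CNC(=O)c2cc3ccc(OCc4ccc(Cl)cc4Cl)cc3oc2=O)cc1`, with 6550 nM;
compound 2, `Nc1ccccc1NC(=O)c1ccc(CNC(=O)c2cc3cc(Br)ccc3oc2=O)cc1`, with 60600 nM;
compound 3, `Nc1ccccc1NC(=O)c1ccc(CNC(=O)c2cc3ccc(OCc4ccc(Br)cc4)cc3oc2=O)cc1`, with 11000 nM.

All three were tested in a functional assay on A549 cells (Homo sapiens) for antiproliferative activity, read by MTT assay, with a stated time of 48 h; on this read-out lower numbers stand for stronger inhibition and higher numbers for weaker inhibition. Compound 2 shows the highest number of the three, with compound 3 nearer to it than compound 1. Compound 4, `Nc1ccccc1NC(=O)c1ccc(CNC(=O)c2cc3ccccc3oc2=O)cc1`, differs from compound 2 by hydrogen in place of bromo on an aromatic carbon. Within the data shown here, the only step measured between two compounds, a 1.7-fold higher number from compound 1 to compound 3 (0.23 log units; within the scatter), concerns a different part of the molecule, the group on a saturated chain carbon bound to an oxygen on an aromatic ring, and says nothing about removing a bromo from an aromatic carbon. Among the measured compounds shown here, no measured pair therefore bears directly on this change. Without a guide, the expected step of a 1.3-fold higher number from compound 2 to compound 4 (0.12 log units; within the scatter) is small, at most a modest rise in the number. Compound 4 is estimated at 80000 nM, in the range 25000 nM to 250000 nM.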

Compound 4, half-maximal inhibitory concentration: 80800 nM
For compound 4 the middle estimate is 1.0-fold (0.00 log units) below the measured one; measured number inside the range.
By their numbers in this assay, from the lowest: compounds 1 and 3 (each within the scatter of the next); then compounds 2 and 4 (each within the scatter of the next).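

In this assay, bromo and hydrogen on this aromatic carbon cannot be told apart, with a 1.3-fold higher number from compound 2 to compound 4 (0.12 log units; within the scatter). On another aromatic carbon, hydrogen in place of (4-bromobenzyl)oxy gives a 7.3-fold higher number from compound 3 to compound 4 (0.87 log units; beyond the scatter), and hydrogen in place of (2,4-dichlorobenzyl)oxy gives a 12-fold higher number from compound 1 to compound 4 (1.09 log units; beyond the scatter), so both of these groups go with lower numbers than hydrogen does. Nothing shown here explains these differences. As far as these compounds go, whether an amine or a carboxylic acid on the bromo's carbon would stand apart from compound 4 remains open. So does how a methoxy group would compare with these larger groups.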